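Benzyloxy replacing ethyl on a chlorinated benzoxazolone acid

The source may report more compounds than this note shows. Statements on the series, on what has been measured and on what is new or still open speak of the compounds shown alone.

Compound 1 `COCCOc1cc2oc(=O)n(CCC(=O)O)c2cc1Cl`: 50100 nM
Compound 2 `CCc1cc2oc(=O)n(CCC(=O)O)c2cc1Cl`: 316 nM

Of the compounds shown here, two sharing one core have been measured in an assay on HEK293 cells for inhibition of kynurenine 3-monooxygenase (Homo sapiens), read by LC-MS, with a stated time of 20 h; a higher number here means a weaker inhibitor, a lower number a stronger inhibitor. Within the data shown here, compound 2 stands at the lowest number of the two, and its only neighbour is compound 1, which sits far higher. Among the measured compounds shown here, the single step between them, a 160-fold lower number from compound 1 to compound 2 (2.20 log units; beyond the scatter), swapped a 2-methoxyethoxy group for ethyl.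

Compound 3 `O=C(O)CCn1c(=O)oc2cc(OCc3ccccc3)c(Cl)cc21` is the next compound, and its difference from compound 2 is benzyloxy in place of ethyl on an aromatic carbon. For the measured compounds named here, the one measured step bears on it directly, since it concerns the same position: compound 1, which carries a group joined through oxygen at that position, gave 50100 nM, while compound 2 with ethyl gave 316 nM. Benzyloxy is also joined through oxygen, yet it differs in size and shape from 2-methoxyethoxy, so only part of that large loss is expected to return. Compound 3 is therefore estimated at 3000 nM in this assay, within 500 nM to 20000 nM, a step of a 9.5-fold higher number from compound 2 to compound 3 (0.98 log units; beyond the scatter) expected toward a weaker inhibitor.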

Compound 3, half-maximal inhibitory concentration: 1580 nM
The estimate for compound 3 lay 1.9-fold (0.28 log units) above the measured number; low and high end bracket the measured number.
By their numbers in this assay, from the lowest: compound 2; then compound 3; then compound 1.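

The two groups joined through oxygen at this position are far apart: the change to phenyl in place of methoxymethyl on the chain gives a 32-fold lower number from compound 1 to compound 3 (1.50 log units; beyond the scatter), so an oxygen link here does not by itself set the number. In this assay, the ring-bearing benzyloxy group, with 8 heavy atoms against the 2 of ethyl, costs much less than 2-methoxyethoxy did, with a 5.0-fold higher number from compound 2 to compound 3 (0.70 log units; beyond the scatter) as only a modest step. Nothing measured here explains either difference.

Phenethyl, which has a carbon where benzyloxy has its oxygen, would separate the effect of that oxygen from the effect of the ring. As far as these compounds go, how a small oxygen-joined group such as methoxy, or a benzyloxy ring carrying a fluorine, would compare also remains open.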